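The source may hold more compounds than are shown below. What is called first, only, known or untested is meant among the compounds shown, and "the series" means these compounds.

Working notes on the amide series. All three measured compounds share a tertiary amide core bearing two aryl groups rich in methoxy substituents. Compound 2 `C=C(C)C(=O)N(Cc1ccc(OC)c(O)c1)c1cc(OC)c(OC)c(OC)c1` gives 200 nM in a functional assay on HCT-116 cells (Homo sapiens) for inhibition, read by MTT assay, with a stated time of 48 h (a lower number here means a stronger inhibitor, a higher number a weaker inhibitor), the lowest of the three numbers recorded. Compound 3 `C/C=C/C(=O)N(Cc1ccc(OC)c(Br)c1)c1cc(OC)c(OC)c(OC)c1` gives 2800 nM in this assay, and compound 1 `C/C=C/C(=O)N(Cc1cc(OC)c(OC)c(OC)c1)c1ccc(OC)c(O)c1` gives 8450 nM in this assay; both gaps to compound 2 lie beyond the scatter, so compound 2 stands as the most potent of the three.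

Compound 4 `COc1ccc(CN(C(=O)C[Se]C#N)c2cc(OC)c(OC)c(OC)c2)cc1O` differs from compound 2 in one place on the carbonyl carbon of the amide: a group of 4 heavy atoms (2 carbon, 1 nitrogen, 1 selenium; no ring) in place of a group of 3 heavy atoms (3 carbon; no ring), on a carbonyl carbon. Within the data shown here, no pair among the measured compounds isolates a change of this kind, so there is no measured step to lean on, and the expectation rests on the value of compound 2 alone. A modest loss is expected, with the step from compound 2 to compound 4 estimated at a 2.5-fold higher number from compound 2 to compound 4 (0.40 log units; beyond the scatter), near the edge of the scatter. For compound 4 in this assay the estimate is 500 nM, with a range from 120 nM to 3000 nM.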

Compound 4, half-maximal inhibitory concentration: 310 nM
For compound 4 the middle estimate is 1.6-fold (0.21 log units) above the measured one; the measured number falls inside the stated range.
By their numbers in this assay, from the lowest: compounds 2 and 4 (each within the scatter of the next); then compound 3; then compound 1.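

In this assay the step is a 1.6-fold higher number from compound 2 to compound 4 (0.19 log units; within the scatter) and so, on a carbonyl carbon whose other neighbour is the amide-type nitrogen, the 1-methylethenyl group and the selenium-bearing nitrile group cannot be told apart. Among these compounds, this is the only measured step at this place, and it shows that a group with a triple bond and a hydrogen-bond acceptor can stand where the 1-methylethenyl group stood without a change beyond the scatter. No measurement on hand bears on what lies behind this result.

Open, as far as these compounds go, is whether a sulfur atom in place of the selenium, or an amine or a carboxylic acid on the same carbonyl carbon, would also stay within the scatter of compound 2 in this assay. Also open, from the compounds shown here alone, is how the selenium-bearing nitrile group would read on the aryl groups of compound 1 and compound 3.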